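Swapping the aryl group on a shared core

The source may report more compounds than this note shows. Statements on the series, on what has been measured and on what is new or still open speak of the compounds shown alone.

Three compounds share one core and differ in their aryl groups. In an ADME assay on microsomes from liver (Homo sapiens) for metabolic stability, tested at 2.5 uM (a lower number here means slower removal, a higher number faster removal of the compound), compound 1 `COc1ccc(S(=O)(=O)c2cnc3c(F)cccc3c2-c2cccc(F)c2)cc1` gives 3.03 mL/min, compound 2 `O=S(=O)(c1cc(Cl)cc(Cl)c1)c1cnc2c(F)cccc2c1-c1cccc(F)c1` gives 1.08 mL/min, and compound 3 `Cc1ccc(S(=O)(=O)c2cnc3c(F)cccc3c2-c2ccc(Cl)cc2)cc1F` gives 2.2 mL/min, the second highest of the three. Among the compounds with values here, the only measured step, a 2.8-fold lower number from compound 1 to compound 2 (0.45 log units; beyond the scatter), concerns the group on the sulfonyl sulfur. Compound 4 `Cc1ccc(S(=O)(=O)c2cnc3c(F)cccc3c2-c2cccc(F)c2)cc1F` differs from compound 3 at another place: 3-fluorophenyl in place of 4-chlorophenyl on an aromatic carbon. Within the data shown here, no measured step bears on this change; compound 1 carries 3-fluorophenyl at that place, and its value and that of compound 3 lie within the scatter of each other. Compound 4 is therefore expected to show a 1.1-fold higher number from compound 3 to compound 4 (0.04 log units; within the scatter), nothing beyond the scatter. The estimate for compound 4 is 2.4 mL/min, between 1.3 mL/min and 4.5 mL/min.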

Compound 4, intrinsic clearance in a liver preparation (reported as CLH), per the amount of preparation that the assay uses: 3.92 mL/min
The estimate for compound 4 lay 1.6-fold (0.21 log units) below the measured number; low and high end bracket the measured number.
By their numbers in this assay, from the lowest: compound 2; then compounds 3, 1 and 4 (each within the scatter of the next).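

In this assay, the first step measured at this aromatic carbon, 3-fluorophenyl in place of 4-chlorophenyl, gives a 1.8-fold higher number from compound 3 to compound 4 (0.25 log units; within the scatter), so this exchange stays inside the scatter. On the sulfonyl sulfur, 3-fluoro-4-methylphenyl in place of 3,5-dichlorophenyl gives a 3.6-fold higher number from compound 2 to compound 4 (0.56 log units; beyond the scatter), whereas in place of 4-methoxyphenyl it gives a 1.3-fold higher number from compound 1 to compound 4 (0.11 log units; within the scatter), which sets 3,5-dichlorophenyl apart from both other groups. No evidence on hand explains these numbers. Still open, as far as these compounds go, is whether an amine or a carboxylic acid at this aromatic carbon would move the number beyond the scatter.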